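Extending the Alkyl Chain of Compound 2

The source may report more compounds than this note shows. Statements on the series, on what has been measured and on what is new or still open speak of the compounds shown alone.

Measured so far in a functional assay on HCT-116 cells (Homo sapiens) for antiproliferative activity, read by MTT assay, with a stated time of 48 h; on this read-out lower numbers stand for stronger inhibition and higher numbers for weaker inhibition:
- Compound 1 `CCCCCC(CCO)n1cnc2c(OC)ncnc21`: > 50000 nM (a limit)
- Compound 2 `CCCCCC(CCO)n1cnc2c(NC)ncnc21`: > 50000 nM (a limit)

Compound 2 gives no number in this assay: its > 50000 nM is a limit. The only other result available is also a limit, as shown by the limit of > 50000 nM in this assay, at which 2 of the 2 values shown sit. Compound 2 therefore has no readable position relative to compound 1.

Compound 3 `CCCCCCCC(CCO)n1cnc2c(NC)ncnc21` keeps the methylamino group of compound 2 and changes the chain: ethyl in place of hydrogen on a saturated chain carbon, six bonds along the chain from an aromatic nitrogen.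

Among the compounds with values here, only one measured step is available, a step that the two limits leave unreadable from compound 1 to compound 2. It gives no size and concerns a different part of the molecule, so it offers no measured guide to a change in the chain. With no readable activity in either measured compound, the expectation is that the added ethyl will bring no change beyond the usual scatter, and compound 3 may well report only a limit again.

The expected step is an at least 1.1-fold lower number from compound 2 to compound 3 (0.04 log units; that floor lies within the scatter). For compound 3 the estimated value is 45000 nM. The expected range for compound 3 runs from 20000 nM to 80000 nM.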

Compound 3, half-maximal inhibitory concentration: 12500 nM
Compound 3: middle estimate off by 3.6-fold (0.56 log units), on the high side; the measured number lies below the stated range.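

Ethyl in place of hydrogen on a saturated chain carbon, six bonds along the chain from an aromatic nitrogen, gives an at least 4.0-fold lower number from compound 2 to compound 3 (0.60 log units; beyond the scatter). Within the data shown here, this is the first readable movement in this assay, and it shows that this place on the chain can shift the read-out, which the earlier pair could not show, as the step between its two limits cannot be read. The step has only a floor, and its true size stays unknown, because compound 2 sits at a limit rather than at a number: the limit of > 50000 nM in this assay, at which 2 of the 3 values shown sit.

Compound 3 is the only compound here with a number, so the compounds shown leave open whether a still longer chain, such as one extended by a further propyl group, would lower the number again or whether the trend stops at this length. They also leave open how far the step depends on the methylamino group, since a methoxy group on the longer chain could behave differently, and whether an amine or a carboxylic acid in place of the terminal hydroxyl would keep the activity of compound 3.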